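Trimming the alkoxy chain of compound 2

The source may hold more compounds than are shown below. What is called first, only, known or untested is meant among the compounds shown, and "the series" means these compounds.

compound 1, `COc1ccc(-c2cnc3nc(N)nc(N4CCN(C(=O)COc5ccccc5)CC4)c3n2)cc1OC`: 4 nM
compound 2, `CC(C)Oc1nc(N)nc2ncc(-c3ccc(C#N)cc3)nc12`: > 10000 nM (a limit)
compound 3, `COc1ccc(-c2cnc3nc(N)nc(N4CCN(Cc5ccccc5)CC4)c3n2)cc1OC`: 900 nM

Of the compounds shown here, three have been measured in a functional assay on cells (T-cell, Homo sapiens) for inhibition; on this read-out higher numbers stand for weaker inhibition and lower numbers for stronger inhibition. Among the compounds with values here, compound 1 gives 4 nM, while compound 3 gives 900 nM, and the one measured step, a 230-fold higher number from compound 1 to compound 3 (2.35 log units; beyond the scatter), concerns an exchange on the amine nitrogen in a ring. In this assay compound 2 gives > 10000 nM, which is a limit of the assay and not a number, so compound 2 stands at the weak end of the values shown: the limit of > 10000 nM in this assay, at which 1 of the 3 values shown sits.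

Compound 4, `CCOc1nc(N)nc2ncc(-c3ccc(C#N)cc3)nc12`, differs from compound 2 by hydrogen in place of methyl on a saturated chain carbon bound to an oxygen on an aromatic ring and a saturated chain carbon. Within the data shown here, no measured step touches this alkoxy chain, and the step from compound 1 to compound 3 concerns a different group on a different core, so it gives no direct guide. Without a comparable precedent the expectation is for no step beyond the scatter, with compound 4 expected to stay close to compound 2: a number no higher from compound 2 to compound 4 (the limit leaves the size open). Compound 4 is therefore estimated at 10000 nM, within a range from 2000 nM to 50000 nM, with a fair chance that the assay again reports only a limit.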

Compound 4, half-maximal inhibitory concentration: > 10000 nM
Compound 4 was reported as a limit (the forecaster's own chance of this, stated with the estimate: 65%); the middle value sits exactly at the limit.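

In this assay compound 4 gives > 10000 nM, which is a limit of the assay and not a number. Compound 2 also stands at a limit, so the change from isopropoxy to ethoxy between compound 2 and compound 4 cannot be read as a step. The compounds shown leave open whether these two alkoxy groups differ at all in this assay.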